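Removing one chloro from compound 3

The source may report more compounds than this note shows. Statements on the series, on what has been measured and on what is new or still open speak of the compounds shown alone.

Compound 1 `CCCCNc1[nH]c2c(F)cc(F)cc2c(=O)c1C(C)=O` gives > 25000 nM as a limit
Compound 2 `CC(C)C(=O)c1c(Nc2ccc(F)c(F)c2F)[nH]c2c(F)cc(F)cc2c1=O` gives > 25000 nM as a limit
Compound 3 `CC(C)C(=O)c1c(Nc2ccc(F)c(F)c2F)[nH]c2c(Cl)cc(Cl)c(Cl)c2c1=O` gives 6400 nM as a plain number

All three entries come from an ADME assay on Vero cells (Chlorocebus sabaeus) for cytotoxicity (a higher number here means that more compound is tolerated, a lower number that less compound is tolerated), and the data are thin, with the limit of > 25000 nM in this assay, at which 2 of the 3 values shown sit, as their main feature. A limit marks the end of what the assay reports and is not a number. For the measured compounds named here, compound 3 with 6400 nM is the only compound here with a true measured value. That value lies under the limit shared by the other two.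

Compound 4 `CC(C)C(=O)c1c(Nc2ccc(F)c(F)c2F)[nH]c2c(Cl)ccc(Cl)c2c1=O` has hydrogen in place of chloro on an aromatic carbon of compound 3 hydrogen in place of chloro on an aromatic carbon and is otherwise unchanged. Going by the values given here, no pair of measured compounds shows this change alone, so the size of the step can only be judged loosely. Compound 3 shares its side groups with compound 2, whose entry is the limit > 25000 nM and which carries no chloro group. That comparison suggests a small upward move in this assay rather than a downward one. The expected change is a 1.9-fold higher number from compound 3 to compound 4 (0.27 log units; within the scatter) and it may prove hard to tell from the usual scatter. For compound 4 the estimate is 12000 nM with 5000 nM to 25000 nM as its expected range.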

Compound 4, half-maximal cytotoxic concentration: 10900 nM
Compound 4: the middle estimate sits 1.1-fold (0.04 log units) above what was measured; low and high end bracket the measured number.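

For the compounds shown here, this is the first change in the set that can be read on its own, with one group swapped at one place and everything else unchanged. In this assay, putting hydrogen in place of chloro on this aromatic carbon, which lies ortho to a chloro group and meta to a chloro group, gives a 1.7-fold higher number from compound 3 to compound 4 (0.23 log units; within the scatter), a step that stays within the scatter. Taken alone, this chloro therefore makes no readable difference to how much compound the cells tolerate, and compound 4 still gives a true measured value rather than a limit, so this single removal does not carry the series up to the end of the assay's range.

From the compounds shown here alone, whether a methoxy group, an amine or a nitrile at this same carbon would shift the number stays open, as does the effect of removing either of the other chloro groups on its own. Most of the earlier entries also offer no number to compare against, since they are limits and not measured values: the limit of > 25000 nM in this assay, at which 2 of the 4 values shown sit.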